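Moving the Bromine Around the Thiophene Ring

The source may report more compounds than this note shows. Statements on the series, on what has been measured and on what is new or still open speak of the compounds shown alone.

Of the compounds shown here, three sharing one core have been measured in an assay on HEK293 cells for inhibition of sodium-dependent dopamine transporter (Homo sapiens), read by scintillation counting, with stated times of 5 min and 1 min; a lower number here means a stronger inhibitor, a higher number a weaker inhibitor. Compound 1 `Cc1scc(C[S+]([O-])C(c2ccccc2)c2ccccc2)c1C` gives 284000 nM. Compound 2 `[O-][S+](Cc1cc(Br)cs1)C(c1ccccc1)c1ccccc1` gives 13700 nM, and compound 3 `[O-][S+](Cc1csc(Br)c1)C(c1ccccc1)c1ccccc1` gives 16600 nM. Compound 3 therefore holds the second highest of the three numbers: the nearest is a 1.2-fold higher number from compound 2 to compound 3 (0.08 log units; within the scatter), within the scatter, while the furthest is a 17-fold lower number from compound 1 to compound 3 (1.23 log units; beyond the scatter), well beyond it.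

Compound 4 `[O-][S+](Cc1ccsc1Br)C(c1ccccc1)c1ccccc1` has not yet been measured. It differs from compound 3 in one place: 2-bromothiophen-3-yl in place of 5-bromothiophen-3-yl on a saturated chain carbon bound to a sulfur. Going by the values given here, the only measured step that moves the bromine around the thiophene while leaving everything else untouched is a 1.2-fold higher number from compound 2 to compound 3 (0.08 log units; within the scatter), which lies within the scatter. The large steps of a 21-fold lower number from compound 1 to compound 2 (1.32 log units; beyond the scatter) and a 17-fold lower number from compound 1 to compound 3 (1.23 log units; beyond the scatter) concern replacing two methyl groups with a bromine and so do not bear directly on this change. The expectation is therefore a step of no more than the scatter in this assay, in no definite direction, estimated as a 1.0-fold lower number from compound 3 to compound 4 (0.02 log units; within the scatter). Compound 4 is estimated at 16000 nM, with a range from 6000 nM to 45000 nM.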

Compound 4, half-maximal inhibitory concentration: 29300 nM
Compound 4: middle estimate off by 1.8-fold (0.26 log units), on the low side; the measured number falls inside the stated range.
By their numbers in this assay, from the lowest: compounds 2, 3 and 4 (each within the scatter of the next, the first and the last beyond it); then compound 1.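

Going by these compounds alone, changing 5-bromothiophen-3-yl to 2-bromothiophen-3-yl on the saturated chain carbon bound to a sulfur stays within the scatter (a 1.8-fold higher number from compound 3 to compound 4 (0.25 log units; within the scatter)), yet the comparison with 4-bromothiophen-2-yl gives the first bromine-for-bromine step beyond it, though only a modest one (a 2.1-fold higher number from compound 2 to compound 4 (0.33 log units; beyond the scatter)). The third bromine compound also stands beyond the scatter from the dimethyl compound, at a modest size (a 9.7-fold lower number from compound 1 to compound 4 (0.99 log units; beyond the scatter)), so all three bromothiophenes shown keep a clear distance from it. Nothing available explains these differences.

The compounds shown leave open whether a chlorine or a single methyl group in place of the bromine would give similar numbers. They also leave open whether a furan or a plain phenyl ring could replace the thiophene.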